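Changing the benzyl ether ring in a prostaglandin receptor antagonist

The source may report more compounds than this note shows. Statements on the series, on what has been measured and on what is new or still open speak of the compounds shown alone.

Compound 1 `O=C(O)c1ccnn1Cc1cc(Br)ccc1OCc1ccccc1`: < 2000 nM
Compound 2 `Cc1cc(C(=O)O)nn1Cc1cc(Br)ccc1OCc1ccc(F)cc1F`: 2.63 nM

Of the compounds shown here, two have so far been measured in a functional assay on CHO-K1 cells for antagonist activity at prostaglandin E2 receptor EP1 subtype (Homo sapiens), read by FLIPR; a higher number here means a weaker inhibitor, a lower number a stronger inhibitor. For compound 1 the result is a limit of the assay and not a number; in this assay compound 1 gives < 2000 nM (the limit of < 2000 nM in this assay, at which 1 of the 2 values shown sits). Compound 2 gives 2.63 nM in this assay, the only actual number shown, so compound 2 stands as the sole fully measured point. Compound 3 `COc1ccccc1COc1ccc(Br)cc1Cn1nc(C(=O)O)cc1C` has not yet been measured. It differs from compound 2 in one place: 2-methoxyphenyl in place of 2,4-difluorophenyl on a saturated chain carbon bound to an oxygen on an aromatic ring. Among the compounds with values here, no step between two measured compounds is available, so the size of this change cannot be read off from earlier data and can only be expected. For compound 3 a moderate weakening is expected, a 3.0-fold higher number from compound 2 to compound 3 (0.48 log units; beyond the scatter), a step somewhat beyond the usual scatter. Compound 3 is therefore estimated at 8 nM, within a range from 2 nM to 40 nM.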

Compound 3, inhibition constant: 69.2 nM
Beside the measured number, compound 3's estimate is 8.7-fold (0.94 log units) below it; measured number above the stated range.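

Within the data shown here, this is the first measured step at this position. Replacing 2,4-difluorobenzyl with 2-methoxybenzyl while the rest of the molecule stays the same gives a 26-fold higher number from compound 2 to compound 3 (1.42 log units; beyond the scatter) in this assay, so the substitution on this ring strongly affects the measured inhibition. Compound 1 could not show this, as it differs from compound 2 in more than one place and its result is a limit of the assay. Compound 3 gives a real number, 69.2 nM, and remains measurable despite the change.

Nothing in the data shown explains why the step is this large. As far as these compounds go, it also remains open whether the change comes from losing the fluorines or from gaining the methoxy group, a question that a 4-fluorophenyl or 2-chlorophenyl ring at this place could help to separate.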